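Taking the nitro group off compound 2

A few compounds are considered here, and "the series" means these few. Any claim that something is new, unique, unknown or untested is made for them only; others in the source may bear on it.

- Compound 1 `OC[C@H]1O[C@H](Oc2ccc(N3CCc4ccccc43)cc2)[C@@H](O)[C@@H](O)[C@@H]1O` gives 31 ug/mL
- Compound 2 `O=[N+]([O-])c1ccc2c(c1)CCN2c1ccc(O[C@H]2O[C@H](CO)[C@@H](O)[C@H](O)[C@@H]2O)c(Cl)c1` gives 3.6 ug/mL

In a physicochemical assay for solubility, using the shake flask method, measured as thermodynamic solubility, with a stated time of 2 h, at pH 6.5 (on this read-out higher numbers stand for higher solubility and lower numbers for lower solubility), compound 2 gives 3.6 ug/mL and holds the lower of the two numbers, with compound 1 higher by more than the usual scatter. Compound 3 `OC[C@H]1O[C@H](Oc2ccc(N3CCc4ccccc43)cc2Cl)[C@@H](O)[C@@H](O)[C@@H]1O` comes from compound 2 through one change hydrogen in place of nitro on an aromatic carbon that puts hydrogen in place of nitro on an aromatic carbon. Going by the values given here, no measured pair shows this change alone, so its size is a judgement. Compound 1 also carries no nitro and gives 31 ug/mL so a rise beyond the scatter is expected, probably stopping short of that number. The estimated step is a 3.3-fold higher number from compound 2 to compound 3 (0.52 log units; beyond the scatter) upward. For compound 3 the expected value is 12 ug/mL with an estimated range from 4.5 ug/mL to 32 ug/mL around it.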

Compound 3, solubility: 21 ug/mL
Compound 3: the middle estimate sits 1.8-fold (0.24 log units) below what was measured; the measured number falls inside the stated range.
By their numbers in this assay, from the lowest: compound 2; then compounds 3 and 1 (each within the scatter of the next).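

In this assay, going by these compounds alone, putting hydrogen in place of nitro on this aromatic carbon gives a 5.8-fold higher number from compound 2 to compound 3 (0.77 log units; beyond the scatter), the first reading of this change on its own. Chloro in place of hydrogen on an aromatic carbon gives a 1.5-fold lower number from compound 1 to compound 3 (0.17 log units; within the scatter), so of these two single changes, only the one at the nitro position moves the number beyond the scatter. No measurement here gives a reason for either step. The compounds shown leave open where another group at the nitro position, such as an amine or a carboxylic acid, would fall relative to compound 2 and compound 3.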